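Thiophene and Methyl Replace Furan Amine on Piperidine Carbon

This account rests on a few compounds, and the source may have more. Where it says the series, first, only, none or still open, it means among the compounds named here.

Compound 1, `C[C@@H](NCC1CCN(CCCc2c[nH]c3ccc(-n4cnnc4)cc23)CC1)c1ccccc1`, gives 14 nM in an assay on CHO cells for displacement of a labelled ligand from 5-hydroxytryptamine receptor 1B (Homo sapiens); on this read-out higher numbers stand for weaker inhibition and lower numbers for stronger inhibition.
Compound 2, `c1ccc2c(c1)CCC2NC1CCN(CCCc2c[nH]c3ccc(-n4cnnc4)cc23)CC1`, gives 280 nM in this assay.
Compound 3, `c1cc(CNC2CCN(CCCc3c[nH]c4ccc(-n5cnnc5)cc34)CC2)co1`, gives 78 nM in this assay.

Compound 3 holds the second highest of these three numbers: a 5.6-fold higher number from compound 1 to compound 3 (0.75 log units; beyond the scatter), and a 3.6-fold lower number from compound 2 to compound 3 (0.56 log units; beyond the scatter). Compound 4, `CN(Cc1ccsc1)C1CCN(CCCc2c[nH]c3ccc(-n4cnnc4)cc23)CC1`, carries the change (methyl((thiophen-3-yl)methyl)amino in place of ((furan-3-yl)methyl)amino on a saturated ring carbon). All measured steps swap the whole group on that saturated ring carbon, and none of them exchanges one five-membered aromatic ring for another or adds a methyl to the amine nitrogen, so they bear on this step only loosely. The two earlier steps show that changes at this position can move this assay modestly or largely in either direction. For compound 4 the number is expected near that of compound 3, at about 90 nM, with a range of 30 nM to 270 nM; this estimate implies a 1.2-fold higher number from compound 3 to compound 4 (0.06 log units; within the scatter).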

Compound 4, half-maximal inhibitory concentration: 35 nM
Estimate against measurement, compound 4: 2.6-fold (0.41 log units) above; the measured number falls inside the stated range.
By their numbers in this assay, from the lowest: compound 1; then compound 4; then compound 3; then compound 2.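

In this assay, among the compounds shown here, methyl((thiophen-3-yl)methyl)amino is the first group on this saturated ring carbon with 0 hydrogen-bond donors, and it still gives a 2.2-fold lower number from compound 3 to compound 4 (0.35 log units; beyond the scatter) in the direction of stronger inhibition. The same group gives an 8.0-fold lower number from compound 2 to compound 4 (0.90 log units; beyond the scatter) as well, but a 2.5-fold higher number from compound 1 to compound 4 (0.40 log units; beyond the scatter) shows that compound 1 keeps the lowest number. Nothing measured here explains these steps. From the compounds shown here alone, compound 4 brings in the thiophene and the methyl together, so the share of each stays open. Going by these compounds, it is also open whether an ethyl on that amine nitrogen would keep the number.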